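From 4-cyanobenzyl to 3-bromobenzyl on a shared core

The compounds below may be only part of what the source reports. "The series", "measured", "known", "first", "only" and "open" are said of these compounds alone.

In a functional assay on U-251 cells (Homo sapiens) for antiproliferative activity, read by MTT assay, with a stated time of 24 h (a lower number here means a stronger inhibitor, a higher number a weaker inhibitor), compound 1 `C#CCOc1ccc2c(=O)c(-c3cc(OC)c(OC)cc3OC)coc2c1` gives 6450 nM and compound 2 `COc1cc(OC)c(-c2coc3cc(OCc4ccc(C#N)cc4)ccc3c2=O)cc1OC` gives 6180 nM. These two values lie within the scatter of each other, so compound 2 stands level with compound 1, and neither can be called the better inhibitor.

Compound 3 `COc1cc(OC)c(-c2coc3cc(OCc4cccc(Br)c4)ccc3c2=O)cc1OC` keeps the core of compound 2 and alters one group, with 3-bromophenyl in place of 4-cyanophenyl on a saturated chain carbon bound to an oxygen on an aromatic ring.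

For the measured compounds named here, only one measured step bears on this change, since it sits at the same place. Swapping ethynyl for 4-cyanophenyl there gave a 1.0-fold lower number from compound 1 to compound 2 (0.02 log units; within the scatter), which lies within the scatter. Going by the values given here, no measured compound carries a bromine, so this single step is a thin guide, and the range has to stay wide. In this assay, the estimated step is a 1.0-fold lower number from compound 2 to compound 3 (0.01 log units; within the scatter), and nothing beyond the scatter is expected in either direction. The expected value for compound 3 is 6000 nM, with an estimated range from 2500 nM to 14000 nM.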

Compound 3, half-maximal inhibitory concentration: > 10000 nM
Compound 3 gave a limit, no number (the forecaster's own chance of this, stated with the estimate: 8%); at least 1.6-fold (0.22 log units) between middle value and limit.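

Compound 3 has a limit and not a number, so the change from 4-cyanobenzyl to 3-bromobenzyl on this saturated chain carbon can be read only as a floor: the limit of > 10000 nM in this assay, at which 1 of the 3 values shown sits.

Against the earlier compounds, that floor reads as an at least 1.6-fold higher number from compound 2 to compound 3 (0.20 log units; that floor lies within the scatter), and the change from ethynyl reads as an at least 1.5-fold higher number from compound 1 to compound 3 (0.19 log units; that floor lies within the scatter). Compounds 1 and 2 suggested that two very different groups at this place could leave the number in this assay unmoved, but compound 3 neither extends that picture with a third measured value nor overturns it, since both floors lie within the scatter and its true value could sit close to the other two or far from them.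

The step from compound 2 to compound 3 exchanges the nitrile for a bromine and also alters where the substituent sits on the ring, so the compounds shown cannot separate those two changes. A 4-bromobenzyl or a 3-cyanobenzyl group would pull them apart, and a plain benzyl group would show how this place reads with neither substituent.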